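Sulfonamide series: phenyl replacing naphthalen-2-yl, metabolic stability

This account rests on a few compounds, and the source may have more. Where it says the series, first, only, none or still open, it means among the compounds named here.

Working notes on three measured sulfonamides sharing one core and one unmeasured analogue. In an ADME assay on S9 fraction from liver (Mus musculus, strain ICR/CD-1) for metabolic stability, read by LC-MS, using NADPH, with a stated time of 5 min, tested at 2 uM (a higher number here means that the compound lasts longer, a lower number that the compound disappears faster), compound 2 `CC1CCN(C2CCN(S(=O)(=O)c3cccc(-c4ccc5ccccc5c4)c3)CC2)CC1` gives 3.4 h. Compound 1 `CC1CCN(C2CCN(S(=O)(=O)c3ccc(Br)cc3OC(F)(F)F)CC2)CC1` gives 0.0833 h in this assay. Compound 3 `CC1CCN(C2CCN(S(=O)(=O)c3ccccc3-c3ccccc3)CC2)CC1` gives only a limit in this assay, namely < 0.1 h, and the limit of < 0.1 h in this assay, at which 1 of the 3 values shown sits, marks that limit. Among the two numbers that are not limits, compound 2 stands highest and compound 1 sits a long way under it, a gap well beyond the usual scatter; no step between compounds differing in a single place is available, so these figures are read only as the pair they are.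

Compound 4 `CC1CCN(C2CCN(S(=O)(=O)c3cccc(-c4ccccc4)c3)CC2)CC1` differs from compound 2 by phenyl in place of naphthalen-2-yl on an aromatic carbon. Among the compounds with values here, the data give no measured step of this kind, and the remaining compounds carry other aryl groups, so the size of the change can only be guessed. A decrease in half-life is expected from compound 2 to compound 4, probably larger than the scatter, and the expected step is a 4.3-fold lower number from compound 2 to compound 4 (0.63 log units; beyond the scatter). For compound 4 the estimated half-life in this assay is 0.8 h, with a range from 0.15 h to 3.5 h.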

Compound 4, half-life: 0.517 h
Beside the measured number, compound 4's estimate is 1.5-fold (0.19 log units) above it; the range from low to high includes it.
By their numbers in this assay, from the lowest: compound 1; then compound 4; then compound 2.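

In this assay the series now has its first measured step in a single place, and it shows that the half-life responds to the aryl group on this aromatic carbon, meta to a large group: phenyl in place of naphthalen-2-yl gives a 6.6-fold lower number from compound 2 to compound 4 (0.82 log units; beyond the scatter). The change takes away one of the two six-membered aromatic rings of carbon only, while hydrogen-bond donors, hydrogen-bond acceptors and net charge stay the same, so in the computed comparison only the ring and its carbon atoms differ between the two groups. No measurement shown gives a cause for this step.

A single pair cannot separate the effect of the second ring from that of the overall size of the group, nor show whether the step would hold on another core or at another position on the ring. Also open, as far as these compounds go, is where a pyridinyl, a cyclohexyl, or a phenyl carrying a fluorine or a nitrile on this same carbon would fall relative to compound 4 and compound 2.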